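Methoxy Pyridyl Swap on a Weak Channel Blocker

This account rests on a few compounds, and the source may have more. Where it says the series, first, only, none or still open, it means among the compounds named here.

The three measured compounds share a core in which an amide joins a methylated five-membered ring to a second five-membered ring that carries an aromatic group. Compound 1 `Cc1cccc(-c2noc(C(C)NC(=O)c3cc(C4CC4)nn3C)n2)c1` is the only one with a numerical result: in an assay on T-REx-293 cells for inhibition of potassium channel subfamily T member 1 (Homo sapiens), read by patch clamp (a lower number here means a stronger inhibitor, a higher number a weaker inhibitor), compound 1 gives 1880 nM. Compound 2 `Cc1cccc(-c2noc([C@H](C)NC(=O)c3cc(C4CC4)n(C)n3)n2)c1` differs from it only in where the methyl sits on the shared core. In this assay compound 2 reaches only a limit, > 30000 nM, so no number is known for it. Compound 3 `Cc1cccc(-c2noc([C@H](C)NC(=O)c3cc(C(F)(F)F)nn3C)n2)n1` carries a trifluoromethyl group and a 6-methylpyridin-2-yl ring. For compound 3 this assay also gives only a limit, > 30000 nM. Compound 3 therefore sits at the weak end of what has been seen, a position shared with one other compound, as the limit of > 30000 nM in this assay, at which 2 of the 3 values shown sit, shows.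

Compound 4 `COc1cc(-c2noc([C@H](C)NC(=O)c3cc(C(F)(F)F)nn3C)n2)cc(C)n1` is not yet measured. It differs from compound 3 in one place: 2-methoxy-6-methylpyridin-4-yl in place of 6-methylpyridin-2-yl on an aromatic carbon. Going by the values given here, no measured pair shows a change of this kind, so its effect is open. The expected step is an at least 1.5-fold lower number from compound 3 to compound 4 (0.17 log units; that floor lies within the scatter). Compound 4 is expected to give roughly 20000 nM, within 5000 nM to 60000 nM.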

Compound 4, half-maximal inhibitory concentration: 505 nM
Compound 4: the middle estimate sits 40-fold (1.60 log units) above what was measured; the measured number lies below the stated range.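

In this assay, replacing 6-methylpyridin-2-yl with 2-methoxy-6-methylpyridin-4-yl on the aromatic carbon between two ring nitrogen atoms gives an at least 59-fold lower number from compound 3 to compound 4 (1.77 log units; beyond the scatter), the first step measured at this position and one well beyond the scatter. The earlier compounds shown here offered no pair that varied this group. Compound 3 reads only as a limit of the assay. Compound 4 gives 505 nM with the rest of its structure the same as in compound 3, so this pair shows that the group alone can turn that reading into a measured number. The true size of the step may be larger than printed, and it is stated only as a floor because the value of compound 3 is a limit and not a number: the limit of > 30000 nM in this assay, at which 2 of the 4 values shown sit.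

The swap adds a methoxy group and also changes how the pyridine ring is attached, and the compounds shown cannot separate these two changes. They also leave open how this assay would read with an ethoxy group or an amine in place of that methoxy group.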